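A Second Ring Hydroxy and Toxicity Toward PC-12 Cells

The source may report more compounds than this note shows. Statements on the series, on what has been measured and on what is new or still open speak of the compounds shown alone.

Three diketones were tested in an ADME assay on PC-12 cells (Rattus norvegicus) for cytotoxicity, read by WST assay, with a stated time of 24 h; on this read-out higher numbers stand for lower toxicity in this test and lower numbers for higher toxicity in this test. Compound 2 `O=C(/C=C/c1cccc(O)c1)CC(=O)/C=C/c1cccc(O)c1O` gives 38000 nM. Compound 1 `O=C(/C=C/c1ccc(O)c(O)c1)CC(=O)/C=C/c1cccc(O)c1O` gives 16000 nM. Compound 3 `O=C(/C=C/c1cccc(O)c1)CC(=O)/C=C/c1cc(O)ccc1O` gives 15000 nM. The change hydroxy in place of hydrogen on an aromatic carbon made the step of a 2.4-fold lower number from compound 2 to compound 1 (0.38 log units; beyond the scatter). The cores of compound 2 and compound 3 differ by 2,5-dihydroxyphenyl in place of 2,3-dihydroxyphenyl on a double-bonded chain carbon bound to a double-bonded chain carbon, which made the step of a 2.5-fold lower number from compound 2 to compound 3 (0.40 log units; beyond the scatter). Compound 4 `O=C(/C=C/c1cc(O)ccc1O)CC(=O)/C=C/c1cc(O)ccc1O` has not yet been measured; it differs from compound 3 by hydroxy in place of hydrogen on an aromatic carbon. This is the same kind of change as that from compound 2 to compound 1, but around the place it is ortho to a large group and para to a hydroxy group rather than ortho to a hydroxy group and para to a large group. Because the earlier step was a 2.4-fold lower number from compound 2 to compound 1 (0.38 log units; beyond the scatter), a step of similar, modest size is expected in this assay: a 1.9-fold lower number from compound 3 to compound 4 (0.27 log units; within the scatter). Compound 4 is estimated at 8000 nM, with a range from 4000 nM to 20000 nM.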

Compound 4, half-maximal cytotoxic concentration: 24000 nM
Beside the measured number, compound 4's estimate is 3.0-fold (0.48 log units) below it; the whole stated range lies below it.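

In this assay, the change from 3-hydroxyphenyl to 2,5-dihydroxyphenyl gave a 1.6-fold higher number from compound 3 to compound 4 (0.20 log units; within the scatter). Within the data shown here, with only two pairs, and the new hydroxy sitting in a different place in each, the result cannot separate an effect of the core from an effect of the place, and it offers no rule for other cores. It does show that, in this series, the size and direction of the step did not carry over from one core to the other: the same change on two cores in this assay, a 2.4-fold lower number (0.38 log units; beyond the scatter) from compound 2 to compound 1 and a 1.6-fold higher number (0.20 log units; within the scatter) from compound 3 to compound 4, 3.8-fold (0.58 log units) apart, beyond the scatter of two such steps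

All the ring substituents shown are hydroxy groups, and the diketone chain stays the same throughout. From the compounds shown here alone, whether a methoxy group, a fluorine or an amine on the ring, or a longer chain, would follow either step remains open.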